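The source may hold more compounds than are shown below. What is called first, only, known or untested is meant among the compounds shown, and "the series" means these compounds.

Compound 1 `CCCn1c(=O)c2nc(-c3cccn3C)[nH]c2n(CCC)c1=O` was examined in an assay on cell membranes for binding affinity to adenosine receptor A1 (Cavia porcellus), read by radioligand binding (a higher number here means a weaker inhibitor, a lower number a stronger inhibitor), where compound 1 gives 140 nM. Among the compounds with values here, only one other compound stands beside it: compound 2 `CC(C)(C)CNc1ncnc2c1ncn2C1O[C@H](CO)[C@@H](O)[C@H]1O`, which in this assay gives 17 nM. Of the two numbers, compound 1 has the higher one, so on what is known so far compound 1 is the weaker of the pair, and the gap to compound 2 lies beyond the usual scatter. Compound 3 `CCCn1c(=O)c2nc([C@@H]3CC4C=CC3C4)[nH]c2n(CCC)c1=O` keeps the core of compound 1 and alters one substituent: a group of 7 heavy atoms (7 carbon; 2 five-membered non-aromatic rings of carbon only) in place of a group of 6 heavy atoms (5 carbon, 1 nitrogen; one five-membered aromatic ring with 1 hetero atom), on an aromatic carbon. Within the data shown here, no measured pair shows this kind of change, so its size can only be expected, not read off. Compound 3 is expected to give a lower number than compound 1, with a step of an 18-fold lower number from compound 1 to compound 3 (1.24 log units; beyond the scatter) in this assay. Taking this into account, compound 3 is estimated at 8 nM in this assay, with a plausible range from 1.5 nM to 40 nM.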

Compound 3, inhibition constant: 4.3 nM
Estimate against measurement, compound 3: 1.9-fold (0.27 log units) above; the measured number falls inside the stated range.
By their numbers in this assay, from the lowest: compound 3; then compound 2; then compound 1.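

In this assay, within the data shown here, the change on the aromatic carbon between two ring nitrogen atoms gives a 33-fold lower number from compound 1 to compound 3 (1.51 log units; beyond the scatter), the first step that can be read at this position, and it shows that the position responds strongly to the group it carries. The 1-methyl-1H-pyrrol-2-yl group, with its ring nitrogen and hydrogen-bond acceptor, can be replaced by a group of carbon only with no hydrogen-bond acceptor, and the number still falls. Nothing available explains this step.

The change alters ring type, atom content and the double bond at once, so the compounds shown leave open which of these carries the step. A plain cyclopentyl or phenyl group could separate these features, while the mirror-image form of the entering group would address its defined stereocentre.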